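A few compounds are considered here, and "the series" means these few. Any claim that something is new, unique, unknown or untested is made for them only; others in the source may bear on it.

Measured compounds in a functional assay on cells (Cancer cell lines, Homo sapiens) for inhibition; on this read-out lower numbers stand for stronger inhibition of growth and higher numbers for weaker inhibition of growth:

- compound 1, `Cc1cc(-c2nc3n(c2/C=N/NC(=N)N)CCS3)c(C)s1`: 17000 nM
- compound 2, `CCOC(=O)c1nc2sc(Cl)cn2c1/C=N\NC(=N)N`: 18200 nM
- compound 3, `Cc1cc(-c2nc3sc(C)cn3c2/C=N/NC(=N)N)c(C)s1`: 9770 nM

All three numbers lie in a narrow band. Compound 1 holds the second highest of the three; the nearest value is that of compound 2, and the gap between them is within the scatter. The value of compound 3 is the furthest from compound 1, yet that gap too is within the scatter, so no order among the three can be read from this assay. Going by the values given here, no pair of measured compounds differs in a single place, so no measured step is available to set a scale for the next change.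

Compound 4, `N=C(N)N/N=C/c1c(-c2cc(Cl)sc2Cl)nc2n1CCS2`, has not yet been measured. It differs from compound 1 as follows: 2,5-dichlorothiophen-3-yl in place of 2,5-dimethylthiophen-3-yl on an aromatic carbon

With nothing in the measured set to show what such a swap does, the expectation is a step from compound 1 to compound 4 of no more than the usual scatter in this assay, in no firm direction. The estimated step is a 1.2-fold lower number from compound 1 to compound 4 (0.08 log units; within the scatter). For compound 4 the expected value in this assay is 14000 nM, with a range from 5000 nM to 40000 nM.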

Compound 4, concentration for 50% growth inhibition: 11200 nM
The estimate for compound 4 lay 1.3-fold (0.10 log units) above the measured number, within the range that was stated.
By their numbers in this assay, from the lowest: compounds 3, 4, 1 and 2 (each within the scatter of the next).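

Placing 2,5-dichlorothiophen-3-yl in place of 2,5-dimethylthiophen-3-yl on an aromatic carbon gives a 1.5-fold lower number from compound 1 to compound 4 (0.18 log units; within the scatter) in this assay as the first step in the series that changes one place only. Going by these compounds alone, this step lies within the scatter, so at this position, next to the ring nitrogen and next to the ring atom that bears a group of 6 heavy atoms, the dimethyl and dichloro thiophenes cannot be told apart on this read-out, and a first measured scale for changes here is now available. Within the data shown here, nothing measured alongside these numbers speaks to the reason for this result, and the single step offers no account of it.

Both substituents on the thiophene change together, so a thiophene carrying one chlorine and one methyl, or an unsubstituted thiophen-3-yl, would be needed to separate their contributions. From the compounds shown here alone, it also remains open whether a more different group at this place, such as a phenyl ring or a morpholine, would give a step beyond the scatter, and whether the same swap on the core of compound 3 would give a step of similar size.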